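A few compounds are considered here, and "the series" means these few. Any claim that something is new, unique, unknown or untested is made for them only; others in the source may bear on it.

Measured compounds in a physicochemical assay for solubility; a higher number here means a more soluble compound, a lower number a less soluble compound:
Compound 1 `COc1cc2cc(C(=O)CC(O)C3CC[N+](C)(Cc4ccccc4)CC3)sc2cc1OC` — compound 1 gives 10000 ug/mL; 8000 ug/mL; 10000 ug/mL (3 entries)
Compound 2 `COC(=O)C[N+]1(C)CCC(CCC(=O)c2cc3cc(OC)c(OC)cc3s2)CC1` — compound 2 gives 60000 ug/mL
Compound 3 `CC[n+]1ccc(CCC(=O)c2cc3cc(OC)c(OC)cc3s2)cc1` — compound 3 gives 25000 ug/mL

Of the two compounds with a single number in this assay, compound 3 has the lower one; compound 2 sits higher by an amount beyond the usual scatter. Compound 1 is known only through several entries, (the several entries of compound 1 in this assay, 10000 ug/mL; 8000 ug/mL; 10000 ug/mL (3 entries)), which is why it is not placed in that order.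

Compound 4 `COCC[n+]1ccc(CCC(=O)c2cc3cc(OC)c(OC)cc3s2)cc1` has not yet been measured. It differs from compound 3 in one place: methoxy in place of hydrogen on a saturated chain carbon, two bonds along the chain from an aromatic nitrogen. Among the compounds with values here, no step between two measured compounds matches this change, so no measured step can guide the expectation. The step from compound 3 to compound 4 in this assay is expected to be small, within or only just beyond the scatter, as a 1.2-fold higher number from compound 3 to compound 4 (0.08 log units; within the scatter). Compound 4 is therefore expected to give about 30000 ug/mL, between 12000 ug/mL and 75000 ug/mL.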

Compound 4, solubility: 33000 ug/mL
Estimate against measurement, compound 4: 1.1-fold (0.04 log units) below; measured number inside the range.
By their numbers in this assay, from the lowest: compounds 3, 4 and 2 (each within the scatter of the next, the first and the last beyond it).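

In this assay, within the data shown here, the change from ethyl to 2-methoxyethyl gives the first measured one-place step, a 1.3-fold higher number from compound 3 to compound 4 (0.12 log units; within the scatter). At this chain carbon, two bonds along the chain from an aromatic nitrogen, methoxy in place of hydrogen therefore leaves the number within the scatter. The data shown offer no measured reason for this result.

On these data alone, whether an amine, a carboxylic acid or a longer chain ending in methoxy at this place would also stay within the scatter remains open. A single step cannot show whether the same holds on the other cores.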